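Benzimidazole series: swapping the pendant aryl substituent

This account rests on a few compounds, and the source may have more. Where it says the series, first, only, none or still open, it means among the compounds named here.

Compound 3 `CC(=O)Nc1cccc(C2CCN(CCCn3c(-c4ccccc4C(F)(F)F)nc4ccccc43)CC2)c1` gives 50 nM in an assay for displacement of a labelled ligand from melanin-concentrating hormone receptor 1 (Homo sapiens), read by fluorescence (a lower number here means a stronger inhibitor, a higher number a weaker inhibitor), the second highest of the three numbers measured, weaker than compound 2 `CC(=O)Nc1cccc(C2CCN(CCCn3c(-c4ccccc4Cl)nc4ccccc43)CC2)c1` at 10 nM and far below compound 1 `CC(=O)Nc1cccc(C2CCN(CCn3c(-c4ccccc4)nc4ccccc43)CC2)c1`, which differs at more than one place and gives 10000 nM. For the measured compounds named here, the only single-point step available, a 5.0-fold higher number from compound 2 to compound 3 (0.70 log units; beyond the scatter), shows that exchanging the group on the pendant phenyl moves the number beyond the scatter even when the position is kept. Compound 4 `COc1ccc(-c2nc3ccccc3n2CCCN2CCC(c3cccc(NC(C)=O)c3)CC2)cc1` is reached by 4-methoxyphenyl in place of 2-(trifluoromethyl)phenyl on an aromatic carbon. Going by the values given here, no measured pair covers a group placed on this part of the pendant ring, so the step between compound 2 and compound 3 is the only guide to the size of the effect, and it says nothing about direction here. Compound 4 is therefore expected to fall in the range spanned by compounds 2 and 3 or somewhat weaker, with the step estimated as a 2.0-fold higher number from compound 3 to compound 4 (0.30 log units; within the scatter). For compound 4 the estimate in this assay is 100 nM, ranging from 20 nM to 600 nM.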

Compound 4, half-maximal inhibitory concentration: 9 nM
Compound 4: the middle estimate sits 11-fold (1.05 log units) above what was measured; the measured number lies below the stated range.
By their numbers in this assay, from the lowest: compounds 4 and 2 (each within the scatter of the next); then compound 3; then compound 1.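

In this assay the exchange at this aromatic carbon gives a 5.6-fold lower number from compound 3 to compound 4 (0.74 log units; beyond the scatter), so the pendant ring can carry a group elsewhere than in 2-(trifluoromethyl)phenyl and the number still changes beyond the scatter. The exchange of 2-chlorophenyl for 4-methoxyphenyl gives a 1.1-fold lower number from compound 2 to compound 4 (0.05 log units; within the scatter), which shows that two differently substituted pendant rings can read alike here and that the group in 2-chlorophenyl is not needed for a number of this size. Nothing available explains either step.

Open, on these data alone, is whether the step from compound 3 follows the methoxy group, the place it occupies or the loss of trifluoromethyl, since these change together. Also open, as far as these compounds go, is how an amine or a carboxylic acid would read in place of the methoxy of 4-methoxyphenyl.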